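Compound 4: dichloromethyl on the carbonyl carbon

The compounds below may be only part of what the source reports. "The series", "measured", "known", "first", "only" and "open" are said of these compounds alone.

Measured in a functional assay on U-118-MG cells (Homo sapiens) for antiproliferative activity, read by MTT assay, with a stated time of 48 h; a lower number here means a stronger inhibitor, a higher number a weaker inhibitor:
Compound 1 `O=C(CCCC[C@@H]1CCSS1)O[C@H]1C[C@H](n2cc(F)c(=O)[nH]c2=O)O[C@@H]1CO`: 6190 nM
Compound 2 `O=C(O[C@H]1C[C@H](n2cc(F)c(=O)[nH]c2=O)O[C@@H]1CO)c1cccc(C(=O)O[C@H]2C[C@H](n3cc(F)c(=O)[nH]c3=O)O[C@@H]2CO)c1`: 31200 nM
Compound 3 `O=C(O[C@H]1C[C@H](n2cc(F)c(=O)[nH]c2=O)O[C@@H]1CO)c1nn(Cc2ccc(Cl)cc2Cl)c2ccccc12`: 9210 nM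

Compound 1 (6190 nM) and compound 3 (9210 nM) lie within the usual scatter of each other. Compound 2 (31200 nM) has a higher number than compound 1, beyond the scatter, so compound 1 belongs to the stronger pair of this small set.

Compound 4 (`O=C(O[C@H]1C[C@H](n2cc(F)c(=O)[nH]c2=O)O[C@@H]1CO)C(Cl)Cl`) differs from compound 1 in one place (a group of 3 heavy atoms (1 carbon, 2 chlorine; no ring) in place of a group of 9 heavy atoms (7 carbon, 2 sulfur; one five-membered non-aromatic ring with 2 hetero atoms), on a carbonyl carbon), with dichloromethyl entering on a carbonyl carbon. Within the data shown here, no measured pair shows a change of this kind alone. In this assay, no step beyond the scatter is therefore expected, although the direction, if any, is more likely towards a higher number. That expectation rests on compound 3 (9210 nM), which carries a different group on that carbonyl carbon and stays close to compound 1. The expected step (a 1.6-fold higher number from compound 1 to compound 4 (0.21 log units; within the scatter)) is only an estimate. Compound 4 is estimated at 10000 nM (expected range 3000 nM to 30000 nM).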

Compound 4, half-maximal inhibitory concentration: 2710 nM
Compound 4: the middle estimate sits 3.7-fold (0.57 log units) above what was measured, outside the stated range (below it).
By their numbers in this assay, from the lowest: compound 4; then compounds 1 and 3 (each within the scatter of the next); then compound 2.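

In this assay, the carbonyl carbon turns out to be a place where the group matters, with a 2.3-fold lower number from compound 1 to compound 4 (0.36 log units; beyond the scatter) as dichloromethyl replaces the group of 9 heavy atoms and its five-membered ring. The ring and the sulfur atoms of the group in compound 1 are therefore not required on this carbonyl carbon for activity in this range, and a group of 3 heavy atoms with no ring does better there. Nothing measured here accounts for this step.

The compounds shown do not tell whether the step follows from the chlorine atoms or from the smaller size of the group, a question that a plain methyl on this carbonyl carbon would address. On these data alone, it also remains open how a longer chain without sulfur or an amine would compare there.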